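Aryl amide swap on two cores, toward the assay ceiling

The source may hold more compounds than are shown below. What is called first, only, known or untested is meant among the compounds shown, and "the series" means these compounds.

Compound 2 `NC(=O)c1c(NC(=O)c2ccccc2F)sc2c1CCN(Cc1c(Cl)cccc1Cl)C2` and compound 1 `NC(=O)c1c(NC(=O)c2ccc(C(F)(F)F)cc2)sc2c1CCN(Cc1c(Cl)cccc1Cl)C2` share one core; compound 3 `NC(=O)c1c(NC(=O)c2ccccc2F)sc2c1CCN(C(=S)Nc1cc(C(F)(F)F)cc(C(F)(F)F)c1)C2` and compound 4 `NC(=O)c1c(NC(=O)c2ccc(C(F)(F)F)cc2)sc2c1CCN(C(=S)Nc1cc(C(F)(F)F)cc(C(F)(F)F)c1)C2` share another, and the difference between the two cores is not broken down here. In a functional assay on HeLa cells (Homo sapiens) for antiproliferative activity, with a stated time of 24 h (a higher number here means a weaker inhibitor, a lower number a stronger inhibitor), compound 2 gives 33000 nM. Compound 1 gives only a limit, > 50000 nM. The change 4-(trifluoromethyl)phenyl in place of 2-fluorophenyl on a carbonyl carbon thus reads as an at least 1.5-fold higher number from compound 2 to compound 1 (0.18 log units; that floor lies within the scatter), its size floored because of the limit of > 50000 nM in this assay, at which 1 of the 3 values shown sits. Compound 3 gives 28000 nM in this assay. Compound 4 carries the same change, (4-(trifluoromethyl)phenyl in place of 2-fluorophenyl on a carbonyl carbon), on the same carbonyl carbon. From compound 3, the expected step is a 1.8-fold higher number from compound 3 to compound 4 (0.25 log units; within the scatter), resting on the measured step from compound 2 to compound 1 and on compound 3 sitting near that limit. Compound 4 is therefore estimated at 50000 nM, between 25000 nM and 100000 nM, likely reported only as a limit.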

Compound 4, half-maximal inhibitory concentration: 49000 nM
Compound 4: the middle estimate sits 1.0-fold (0.01 log units) above what was measured; measured number inside the range.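

In this assay, 4-(trifluoromethyl)phenyl in place of 2-fluorophenyl on a carbonyl carbon reads as a 1.8-fold higher number from compound 3 to compound 4 (0.24 log units; within the scatter). Set beside the same change on the other core, the comparison stands thus: the same change on two cores in this assay, an at least 1.5-fold higher number (0.18 log units; that floor lies within the scatter) from compound 2 to compound 1 and a 1.8-fold higher number (0.24 log units; within the scatter) from compound 3 to compound 4; the limit leaves it open whether they differ Nothing here separates the two cores, but this does not show that the change carries over by the same amount, as one step is only a floor and the other lies within the scatter: the limit of > 50000 nM in this assay, at which 1 of the 4 values shown sits.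

The compounds shown leave open whether this change reads beyond the scatter on any core in the series. They also leave open how an amine or a carboxylic acid on the aryl ring would read on these two cores.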